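Aryl-to-benzyl swap on the ring nitrogen of compound 1

The compounds below may be only part of what the source reports. "The series", "measured", "known", "first", "only" and "open" are said of these compounds alone.

Two compounds of the shared core have numbers in a functional assay on ECa-109 cells (Homo sapiens) for inhibition, read by MTT assay, with a stated time of 72 h; on this read-out lower numbers stand for stronger inhibition and higher numbers for weaker inhibition. Compound 1 `Cc1ccc(-n2cc(CSC(=S)N3CCN(C(=O)OC(C)(C)C)CC3)nn2)cc1` gives 114000 nM, the highest of the two. Compound 2 `COc1cc(Cn2cc(CSC(=S)N3CCN(C(=O)OC(C)(C)C)CC3)nn2)cc(OC)c1OC` gives 44400 nM, a lower number beyond the scatter. Compound 3 `CC(C)(C)OC(=O)N1CCN(C(=S)SCc2cn(Cc3ccccc3Cl)nn2)CC1` is not yet measured; it differs from compound 1 by 2-chlorobenzyl in place of 4-methylphenyl on an aromatic nitrogen. For the measured compounds named here, no measured pair isolates this change, but compound 2 also carries a benzyl group and gives the lower number, so a moderate fall in number is expected as the step of a 1.9-fold lower number from compound 1 to compound 3 (0.28 log units; within the scatter). Compound 3 is estimated at 60000 nM, within 20000 nM to 160000 nM.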

Compound 3, half-maximal inhibitory concentration: 11900 nM
Compound 3: the middle estimate sits 5.0-fold (0.70 log units) above what was measured; the measured number lies below the stated range.
By their numbers in this assay, from the lowest: compound 3; then compound 2; then compound 1.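

In this assay, for the compounds shown here, the group on the aromatic nitrogen proves to be a place that responds: 2-chlorobenzyl in place of 4-methylphenyl gives a 9.6-fold lower number from compound 1 to compound 3 (0.98 log units; beyond the scatter), the first measured single-place step and one beyond the scatter. No measurement on hand accounts for this step.

Still open, going by these compounds, is whether the step belongs to the benzyl link or to the chlorine, as the swap alters both. Unsubstituted benzyl and 2-chlorophenyl on the same nitrogen would separate the two.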